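Furan to Oxazole on the Amide Carbonyl

The source may hold more compounds than are shown below. What is called first, only, known or untested is meant among the compounds shown, and "the series" means these compounds.

Measured compounds in a functional assay (Sus scrofa) with sulfonylurea receptors; K-ATP channels (Homo sapiens) as the target; on this read-out higher numbers stand for an effect only at larger amounts of compound and lower numbers for an effect already at smaller amounts:
Compound 1, `O=C(Nc1c(C(O)(C(F)(F)F)C(F)(F)F)ccc2ccccc12)C1CCC1`, gives 81.3 nM.
Compound 2, `O=C(Nc1c(C(O)(C(F)(F)F)C(F)(F)F)ccc2ccccc12)c1ccco1`, gives 182 nM.

Of the two measured compounds, compound 2 shows the highest number; its nearest neighbour is compound 1, and the step of a 2.2-fold higher number from compound 1 to compound 2 (0.35 log units; beyond the scatter) lies beyond the scatter, though it is modest. Compound 3, `O=C(Nc1c(C(O)(C(F)(F)F)C(F)(F)F)ccc2ccccc12)c1cnco1`, differs from compound 2 by 1,3-oxazol-5-yl in place of furan-2-yl on a carbonyl carbon. Among the measured compounds shown here, the only measured step, a 2.2-fold higher number from compound 1 to compound 2 (0.35 log units; beyond the scatter), replaces a saturated ring on the carbonyl carbon with a five-membered aromatic ring with one hetero atom; the step to compound 3 instead exchanges one five-membered aromatic ring for another of the same size, and no measured pair covers a change of that kind. For the measured compounds named here, with no direct precedent, the expectation in this assay is a number close to that of compound 2, with no step beyond the scatter in either direction, the uncertainty being wider than for a change already seen. Compound 3 is therefore estimated at 200 nM, within a range of 80 nM to 500 nM. That estimate means an expected step of a 1.1-fold higher number from compound 2 to compound 3 (0.04 log units; within the scatter).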

Compound 3, half-maximal effective concentration: 302 nM
Estimate against measurement, compound 3: 1.5-fold (0.18 log units) below; the measured number falls inside the stated range.
By their numbers in this assay, from the lowest: compound 1; then compounds 2 and 3 (each within the scatter of the next).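

In this assay, the exchange of furan-2-yl for 1,3-oxazol-5-yl on the carbonyl carbon gives a 1.7-fold higher number from compound 2 to compound 3 (0.22 log units; within the scatter), so this place accepts a second hetero atom in the five-membered aromatic ring, and a rise from 1 to 2 hydrogen-bond acceptors, without a step beyond the scatter. Set against the saturated ring, the same group gives a 3.7-fold higher number from compound 1 to compound 3 (0.57 log units; beyond the scatter), which makes compound 1 the only one of the three separated from both others by steps beyond the scatter, and the one with the lowest number. Nothing available here accounts for either step, and the numbers alone cannot supply an explanation.

From the compounds shown here alone, whether the lower number of compound 1 belongs to cyclobutyl alone or extends to other saturated rings remains open, and a cyclopentyl or a piperidine on the carbonyl carbon would speak to that. Also open, going by these compounds, is how a phenyl ring, a pyridine or a longer alkyl chain would compare at this place, and whether the furan-2-yl to 1,3-oxazol-5-yl exchange would read the same on another core.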